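Replacing the amide group of compound 3

This account rests on a few compounds, and the source may have more. Where it says the series, first, only, none or still open, it means among the compounds named here.

compound 1 `CCn1c(C(=O)NCCN(C)C)ccc1C(CC)(CC)c1ccc(OCC(O)C(C)(C)C)c(C)c1` gives 660 nM
compound 2 `CCn1c(C(=O)NCC(OC)OC)ccc1C(CC)(CC)c1ccc(OCC(O)C(C)(C)C)c(C)c1` gives > 50000 nM (a limit)
compound 3 `C=CCN(C)C(=O)c1ccc(C(CC)(CC)c2ccc(OCC(O)C(C)(C)C)c(C)c2)n1CC` gives > 50000 nM (a limit)

All three compounds were read in a functional assay on MCF7 cells (Homo sapiens), read by MTT assay, with a stated time of 48 h (on this read-out higher numbers stand for weaker inhibition and lower numbers for stronger inhibition), and only compound 1 gives a number there. Compound 3 has no number: it stands at the limit of > 50000 nM in this assay, at which 2 of the 3 values shown sit.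

Compound 4 `CCn1c(C(=O)N(CCC#N)CCC#N)ccc1C(CC)(CC)c1ccc(OCC(O)C(C)(C)C)c(C)c1` keeps the core of compound 3 but loses the allyl(methyl)amino group on the carbonyl carbon (a group of 9 heavy atoms (6 carbon, 3 nitrogen; no ring) in place of a group of 5 heavy atoms (4 carbon, 1 nitrogen; no ring), on a carbonyl carbon). Among the compounds with values here, three measured steps bear on this. With dimethoxymethyl in place of (dimethylamino)methyl, the series shows an at least 75-fold higher number from compound 1 to compound 2 (1.87 log units; beyond the scatter), a large step. Compound 4 likewise has no (2-(dimethylamino)ethyl)amino group, and the same loss shows an at least 75-fold higher number from compound 1 to compound 3 (1.87 log units; beyond the scatter), also large. The two limits leave the third comparison open: a step that the two limits leave unreadable from compound 2 to compound 3.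

Compound 4 is therefore expected to stay with the two limits and not to approach compound 1. No step beyond the scatter is expected in this assay, and the expected size is a number no higher from compound 3 to compound 4 (the limit leaves the size open). The estimate for compound 4 is 50000 nM, with an expected range from 15000 nM to 100000 nM.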

Compound 4, half-maximal inhibitory concentration: 480 nM
Compound 4: middle estimate off by 100-fold (2.02 log units), on the high side, and the stated range ends above it.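

In this assay, within the data shown here, the earlier compounds left the (2-(dimethylamino)ethyl)amino group as the only one on the carbonyl carbon linked to a measured number, yet compound 4 lacks that group and the result is a 1.4-fold lower number from compound 1 to compound 4 (0.14 log units; within the scatter), so this group is not required for activity on this core. The group of 9 heavy atoms also separates itself clearly from the other replacements, with an at least 100-fold lower number from compound 3 to compound 4 (2.01 log units; beyond the scatter) and an at least 100-fold lower number from compound 2 to compound 4 (2.01 log units; beyond the scatter), which shows that the outcome at this position depends on which group replaces the (2-(dimethylamino)ethyl)amino group, not simply on its loss. Compound 2 and compound 3 each remain at a limit, not a number: the limit of > 50000 nM in this assay, at which 2 of the 4 values shown sit.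

The compounds shown leave open which part of the group of 9 heavy atoms matters, and whether a single 2-cyanoethyl chain, a longer chain ending in a nitrile or a cyclic amine such as morpholine would stay at the same level. They also do not explain why allyl(methyl)amino and the group of 9 heavy atoms, both with no hydrogen-bond donors, lie so far apart in this assay.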